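The source may hold more compounds than are shown below. What is called first, only, known or untested is meant among the compounds shown, and "the series" means these compounds.

Compound 1 has the structure `COc1cc(-c2cc(/C=C/C(=O)c3ccc(N)cc3)[nH]n2)cc(OC)c1OC`. In a functional assay on NCI-H322M cells (Homo sapiens) for cytotoxicity, read by sulforhodamine B assay, with a stated time of 48 h, tested at 10 uM (a higher number here means a weaker effect of the compound at the concentration tested, a lower number a stronger effect), compound 1 gives -32%. A second compound, compound 2, with the structure `COc1ccc(-c2cc(/C=C/C(=O)c3ccc(OC)c(OC)c3)[nH]n2)cc1`, gives in this assay -32%. Compound 1 therefore stands level with compound 2 at the digits shown; the two readings lie within the usual scatter of each other, so nothing separates them. For the measured compounds named here, no pair of measured compounds here differs in a single place, so no measured step is available to lean on.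

Compound 3, with the structure `COc1cc(-c2cc(/C=C/C(=O)c3ccc(Cl)c(Cl)c3)[nH]n2)cc(OC)c1OC`, is the next compound to be examined in this assay. It differs from compound 1 in one place: 3,4-dichlorophenyl in place of 4-aminophenyl on a carbonyl carbon. Going by the values given here, nothing among the measured compounds shows what exchanging one group on that carbonyl carbon for another does to the read-out. The step of a number 7 percentage points higher from compound 1 to compound 3 (within the scatter) is expected to be small, not beyond the scatter, and it could point either way. On that basis compound 3 is expected to give -25% in this assay, with a range from -60% to 10%.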

Compound 3, a percentage reported as activity, at one concentration (the size of the read-out at that concentration, not a potency): 59%
Beside the measured number, compound 3's estimate is 84 percentage points below it, outside the stated range (above it).
By their numbers in this assay, from the lowest: compounds 1 and 2 (each within the scatter of the next); then compound 3.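

In this assay, the group on the carbonyl carbon proves to matter a great deal: putting 3,4-dichlorophenyl in place of 4-aminophenyl gives a number 91 percentage points higher from compound 1 to compound 3 (beyond the scatter), a much weaker effect at the concentration tested. The two earlier compounds could not show this, since they differ in more than one place and so offered no single change to read. This one exchange, with the rest of the structure held constant, is enough to turn a negative read-out into a clearly positive one, so this position is far from indifferent, although the exchange removes the nitrogen of 4-aminophenyl and brings in two chlorines at once, and a single step cannot tell those parts apart.

Still open, going by these compounds, is whether the stronger effect of compound 1 depends on the amine itself or whether the chlorines are what weakens compound 3, a question that a plain phenyl or a 4-chlorophenyl on the same carbonyl carbon would help to settle. Nothing measured here gives a reason for the size of this step.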